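The source may report more compounds than this note shows. Statements on the series, on what has been measured and on what is new or still open speak of the compounds shown alone.

Compound 2 `C#CCCCCN1CCC(c2ccc(-c3cc(C(=O)O)cc4cc(-c5ccc(C(F)(F)F)cc5)ccc34)cc2)CC1` stands at the lower of the two numbers in a functional assay on the whole organism (strain ICR) for inhibition, with Mus musculus as the target, with stated times of 7 days and 0.5 h, at a dose of 10 umol/kg by the intraperitoneal route (on this read-out lower numbers stand for less inhibition and higher numbers for more inhibition at the one dose given (going by the name of the read-out)), giving 52.4%, while compound 1 `CC(=O)N1CCC(c2ccc(-c3cc(C(=O)O)cc4cc(-c5ccc(C(F)(F)F)cc5)ccc34)cc2)CC1` gives 83.3%. Compound 3 `CCC(=O)N1CCC(c2ccc(-c3cc(C(=O)O)cc4cc(-c5ccc(C(F)(F)F)cc5)ccc34)cc2)CC1` differs from compound 2 by propanoyl in place of hex-5-yn-1-yl on an amine nitrogen in a ring. Among the compounds with values here, the one measured step that bears on this is a number 30.9 percentage points lower from compound 1 to compound 2 (beyond the scatter), a change that compound 3 nearly reverses, as propanoyl and acetyl both carry a carbonyl. A large upward step in this assay is therefore expected for compound 3, close to the number of compound 1. Compound 3 is estimated to give 78%, between 60% and 92%, an expected step of a number 25.6 percentage points higher from compound 2 to compound 3 (beyond the scatter).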

Compound 3, a percentage reported as inhibition, in the whole organism at one dose (the size of the read-out at that dose, not a potency): 32.9%
Compound 3: the middle estimate sits 45.1 percentage points above what was measured; measured number outside the range, below it.
By their numbers in this assay, from the lowest: compound 3; then compound 2; then compound 1.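

In this assay, a carbonyl on the ring nitrogen does not by itself secure a high number: propanoyl in place of hex-5-yn-1-yl gives a number 19.5 percentage points lower from compound 2 to compound 3 (beyond the scatter). Adding only a methyl to the acyl chain gives a number 50.4 percentage points lower from compound 1 to compound 3 (beyond the scatter), so acetyl and propanoyl do not behave alike and this position responds strongly to a very small change. Nothing measured here accounts for this. As far as these compounds go, whether butanoyl, a longer acyl chain, would stand lower still remains open, as does where the free secondary amine on this ring nitrogen would stand.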